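Swapping a Chloroethyl Amide for a Propyl Urea

The source may report more compounds than this note shows. Statements on the series, on what has been measured and on what is new or still open speak of the compounds shown alone.

Three compounds share one core and differ only in the group on the carbonyl carbon. Compound 1 `CC(C)C(=O)Nc1ccc(S(=O)(=O)Oc2ccccc2I)cc1` gives 3300 nM in a functional assay on HT-1080 cells (Homo sapiens) for antiproliferative activity, read by sulforhodamine B assay, with a stated time of 48 h; a higher number here means a weaker inhibitor, a lower number a stronger inhibitor. Compound 2 `CC(C)(C)C(=O)Nc1ccc(S(=O)(=O)Oc2ccccc2I)cc1` gives 2600 nM in this assay; the step of a 1.3-fold lower number from compound 1 to compound 2 (0.10 log units; within the scatter) is small. Compound 3 `O=C(CCCl)Nc1ccc(S(=O)(=O)Oc2ccccc2I)cc1` gives 4200 nM in this assay, the largest of the three numbers, yet a 1.3-fold higher number from compound 1 to compound 3 (0.10 log units; within the scatter) and a 1.6-fold higher number from compound 2 to compound 3 (0.21 log units; within the scatter) both sit inside the scatter. Compound 4 `CCCNC(=O)Nc1ccc(S(=O)(=O)Oc2ccccc2I)cc1` carries the next change: propylamino in place of 2-chloroethyl on a carbonyl carbon. Within the data shown here, no measured step covers this swap; the three steps that exist all touch the same carbonyl carbon and none moved the number beyond the scatter, so a step of a 1.1-fold lower number from compound 3 to compound 4 (0.02 log units; within the scatter) in this assay is expected, meaning little change. Compound 4 is therefore estimated to give 4000 nM, within 1500 nM to 11000 nM.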

Compound 4, half-maximal inhibitory concentration: 700 nM
Compound 4: middle estimate off by 5.7-fold (0.76 log units), on the high side; measured number outside the range, below it.
By their numbers in this assay, from the lowest: compound 4; then compounds 2, 1 and 3 (each within the scatter of the next).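

In this assay, among these compounds, the group on this carbonyl carbon does matter: a 6.0-fold lower number from compound 3 to compound 4 (0.78 log units; beyond the scatter) and likewise a 3.7-fold lower number from compound 2 to compound 4 (0.57 log units; beyond the scatter) and a 4.7-fold lower number from compound 1 to compound 4 (0.67 log units; beyond the scatter) all lie beyond the scatter, which no step among the earlier compounds did. What enters is propylamino, with a nitrogen on the carbonyl carbon and a hydrogen-bond donor that 2-chloroethyl lacks, turning the amide into a urea.

As far as these compounds go, whether the nitrogen or the propyl chain carries the change stays open, and an ethylamino, butylamino or dimethylamino group here could help tell them apart. No measurement on hand accounts for the lower number.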